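From dimethylamino to cyano: an expected cytotoxicity for compound 4

The source may hold more compounds than are shown below. What is called first, only, known or untested is meant among the compounds shown, and "the series" means these compounds.

compound 1 `COc1ccc(-c2ccc(Cl)cc2)c(COc2ccc(-c3nc4cc(C(=O)O)ccc4n3C3CCCCC3)cc2)c1`: 24000 nM
compound 2 `CN(C)S(=O)(=O)c1ccc(-c2ccc(Cl)cc2)c(COc2ccc(-c3nc4cc(C(=O)O)ccc4n3C3CCCCC3)cc2)c1`: 26000 nM
compound 3 `CN(C)c1ccc(-c2ccc(Cl)cc2)c(COc2ccc(-c3nc4cc(C(=O)O)ccc4n3C3CCCCC3)cc2)c1`: 30000 nM

These values come from a functional assay on Huh-5-2 cells (Homo sapiens), read by MTT assay; on this read-out lower numbers stand for higher toxicity in this test and higher numbers for lower toxicity in this test. Compound 3, at 30000 nM, stands within the scatter of both compound 1 and compound 2. Compound 4 `N#Cc1ccc(-c2ccc(Cl)cc2)c(COc2ccc(-c3nc4cc(C(=O)O)ccc4n3C3CCCCC3)cc2)c1` has cyano in place of dimethylamino on an aromatic carbon, meta to a large group and para to a 4-chlorophenyl group (cyano in place of dimethylamino on an aromatic carbon).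

The measured steps bearing on this change altered the group at the same place. They are a 1.1-fold higher number from compound 1 to compound 2 (0.03 log units; within the scatter), a 1.3-fold higher number from compound 1 to compound 3 (0.10 log units; within the scatter) and a 1.2-fold higher number from compound 2 to compound 3 (0.06 log units; within the scatter). All three are small and lie within the scatter, but none of them involves cyano, so they offer only indirect guidance. In this assay, no change beyond the scatter is therefore expected, in either direction. The expected change is a 1.1-fold lower number from compound 3 to compound 4 (0.05 log units; within the scatter). Compound 4 is estimated at 27000 nM, with an expected range of 14000 nM to 50000 nM.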

Compound 4, half-maximal cytotoxic concentration: 23000 nM
Beside the measured number, compound 4's estimate is 1.2-fold (0.07 log units) above it, and the stated range covers the measured number.
By their numbers in this assay, from the lowest: compounds 4, 1, 2 and 3 (each within the scatter of the next).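

In this assay, cyano on this aromatic carbon, para to a 4-chlorophenyl group, stays within the scatter of all three earlier groups, with a 1.3-fold lower number from compound 3 to compound 4 (0.12 log units; within the scatter) against dimethylamino, a 1.1-fold lower number from compound 2 to compound 4 (0.05 log units; within the scatter) against dimethylsulfamoyl and a 1.0-fold lower number from compound 1 to compound 4 (0.02 log units; within the scatter) against methoxy. The earlier compounds shown here showed this flat picture only for those three groups; it now extends to a group with a triple bond outside aromatic rings, and the four compounds cannot be placed in any order at this position. Nothing available gives a cause for this result.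

From the compounds shown here alone, it remains open whether a primary amine, a carboxylic acid or a longer chain such as butoxy at this position would also stay within the scatter. The same holds for whether this tolerance of change persists when the 4-chlorophenyl group is replaced.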